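Variation at the triple-bonded carbon: working notes

The source may report more compounds than this note shows. Statements on the series, on what has been measured and on what is new or still open speak of the compounds shown alone.

Measured compounds:
compound 1 `Cc1ccc(C#Cc2cn(C/C=C\CN3C(=O)c4ccccc4C3=O)c(=O)[nH]c2=O)cc1` — 238000 nM
compound 2 `O=C1c2ccccc2C(=O)N1C/C=C\Cn1cc(C#CCCc2ccccc2)c(=O)[nH]c1=O` — 168000 nM

Compound 2 holds the lowest of the two numbers in a functional assay on CCRF-CEM cells (Homo sapiens) for antiproliferative activity, read by MTT assay, with a stated time of 3 days; a lower number here means a stronger inhibitor, a higher number a weaker inhibitor. Among the compounds with values here, its nearest neighbour is compound 1, and the only measured step, a 1.4-fold lower number from compound 1 to compound 2 (0.15 log units; within the scatter), lies within the scatter, so the two compounds cannot be ordered against each other on this assay.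

Compound 3 `CCCCc1ccc(C#Cc2cn(C/C=C\CN3C(=O)c4ccccc4C3=O)c(=O)[nH]c2=O)cc1` is the next point. Its change from compound 2 is 4-butylphenyl in place of phenethyl on a triple-bonded carbon. The 4-butylphenyl of compound 3 matches the 4-methylphenyl of compound 1 apart from the length of the chain, so the step from compound 2 to compound 3 largely reverses the measured step from compound 1 to compound 2, which was within the scatter. Within the data shown here, no measured step speaks to the length of the chain itself. Compound 3 is therefore expected to show no step beyond the scatter, a 1.2-fold higher number from compound 2 to compound 3 (0.08 log units; within the scatter), with compound 3 and compound 1 both being the reference points. The estimate for compound 3 in this assay is 200000 nM, with a range from 80000 nM to 500000 nM.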

Compound 3, half-maximal inhibitory concentration: 23000 nM
Compound 3: the middle estimate sits 8.7-fold (0.94 log units) above what was measured, and the stated range ends above it.
By their numbers in this assay, from the lowest: compound 3; then compounds 2 and 1 (each within the scatter of the next).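

In this assay, the group on the triple-bonded carbon can change the read-out, which the earlier step within the scatter did not show: replacing phenethyl with 4-butylphenyl gives a 7.3-fold lower number from compound 2 to compound 3 (0.86 log units; beyond the scatter). The comparison with 4-methylphenyl isolates the chain on the aromatic ring, as propyl in place of hydrogen on a saturated chain carbon bound to an aromatic carbon gives a 10-fold lower number from compound 1 to compound 3 (1.01 log units; beyond the scatter), so the presence of the aromatic ring alone does not set the level of activity among these compounds. Nothing available bears on the reason for either step.

With only methyl and butyl compared on this aromatic ring, the compounds shown do not establish how the read-out follows chain length, and neither an ethyl group nor a longer chain such as hexyl tests whether the trend is graded, continues or reverses. They also leave open whether a plain carbon chain is required or whether the same chain carrying an amine or a carboxylic acid would retain the lower number seen with compound 3.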